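This account rests on a few compounds, and the source may have more. Where it says the series, first, only, none or still open, it means among the compounds named here.

Compound 1 `C[Se]/C(=N\C(=O)c1ccco1)NC(=O)c1ccco1` was tested in a functional assay on PC-3 cells (Homo sapiens) for cytotoxicity, read by MTT assay, with a stated time of 72 h; on this read-out lower numbers stand for stronger inhibition of growth and higher numbers for weaker inhibition of growth; in that test compound 1 gives 56700 nM, the higher of the two numbers in hand, while compound 2 `CS/C(=N\C(=O)c1cc2ccccc2s1)NC(=O)c1cc2ccccc2s1` gives 39400 nM, a gap that lies within the scatter of this assay. Compound 3 `CS/C(=N\C(=O)c1ccco1)NC(=O)c1ccco1` is still to be measured. It differs from compound 1 by a group of 2 heavy atoms (1 carbon, 1 sulfur; no ring) in place of a group of 2 heavy atoms (1 carbon, 1 selenium; no ring), on a carbon with a double bond to nitrogen. Going by the values given here, no measured pair shows this exchange on its own, so the expected step of a 1.1-fold lower number from compound 1 to compound 3 (0.05 log units; within the scatter) is no change beyond the scatter. Compound 3 is therefore estimated at 50000 nM, with a range from 20000 nM to 125000 nM.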

Compound 3, concentration for total growth inhibition: > 100000 nM
Compound 3 ended at the assay's limit; the forecaster's own chance of this, stated with the estimate: 10%; middle value at least 2.0-fold (0.30 log units) away from the limit.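

Going by these compounds alone, exchanging the selenium-bearing group for methylsulfanyl, on a carbon with a double bond to nitrogen, gives an at least 1.7-fold higher number from compound 1 to compound 3 (0.24 log units; that floor lies within the scatter) in this assay, the only direct reading of this exchange here. That floor does not show a change beyond the scatter, though a larger one remains possible. For compound 3, > 100000 nM is a limit of the assay and not a number, so the true size of the step stays unread: the limit of > 100000 nM in this assay, at which 1 of the 3 values shown sits.

The compounds shown leave open how an amine or a longer chain on this carbon would read. They also leave open whether the same exchange would behave alike on the core of compound 2.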